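Quinolin-4-yl in Place of Methoxypyridinyl on Compound 3

A few compounds are considered here, and "the series" means these few. Any claim that something is new, unique, unknown or untested is made for them only; others in the source may bear on it.

Of the compounds shown here, three sharing one core have been measured in a functional assay on the whole organism (blood) with Rattus norvegicus as the target, with stated times of 24 h and 1 h, at a dose of 5 mg/kg by the intraperitoneal route; on this read-out lower numbers stand for a weaker effect and higher numbers for a stronger effect at the one dose given. Compound 1 `COc1ccc(Cl)cc1C(=O)NCCC1CCN(S(=O)(=O)NC(=O)NC2CCCCC2)CC1` gives 25%, compound 2 `O=C(NC1CCCCC1)NS(=O)(=O)N1CCC(CCNC(=O)c2csnn2)CC1` gives 19%, and compound 3 `COc1ncccc1C(=O)NCCC1CCN(S(=O)(=O)NC(=O)NC2CCCCC2)CC1` gives 33%. Compound 3 therefore holds the highest of the three numbers: its nearest neighbour, compound 1, lies within the scatter, while compound 2 lies beyond it, as the step of a number 14 percentage points higher from compound 2 to compound 3 (beyond the scatter) shows. Compound 4 `O=C(NC1CCCCC1)NS(=O)(=O)N1CCC(CCNC(=O)c2ccnc3ccccc23)CC1` has not yet been measured. It differs from compound 3 in one place: quinolin-4-yl in place of 2-methoxypyridin-3-yl on a carbonyl carbon. Among the compounds with values here, the steps that bear on this exchange of the group on the carbonyl carbon are a number 8 percentage points higher from compound 1 to compound 3 (within the scatter) and a number 14 percentage points higher from compound 2 to compound 3 (beyond the scatter), together with a number 6 percentage points lower from compound 1 to compound 2 (within the scatter); two of three such exchanges stayed within the scatter, and the largest was only modest. He thus expects no step beyond the scatter from compound 3 to compound 4, that is a number 5 percentage points lower from compound 3 to compound 4 (within the scatter), and estimates that compound 4 gives 28% in this assay, within a range from 10% to 48%.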

Compound 4, a percentage reported as activity, at one dose (the size of the read-out at that dose, not a potency): 16%
Compound 4: the middle estimate sits 12 percentage points above what was measured, and the stated range covers the measured number.
By their numbers in this assay, from the lowest: compounds 4, 2, 1 and 3 (each within the scatter of the next, the first and the last beyond it).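

In this assay, the group on the carbonyl carbon can move the read-out beyond the scatter in the downward direction from compound 3, giving a number 17 percentage points lower from compound 3 to compound 4 (beyond the scatter). The other two exchanges stay small, with a number 3 percentage points lower from compound 2 to compound 4 (within the scatter) and a number 9 percentage points lower from compound 1 to compound 4 (within the scatter), so the two aromatic rings of quinolin-4-yl leave compound 4 level with compound 1 and compound 2, and only compound 3 stands apart from it. No measurement at hand accounts for this difference.

From the compounds shown here alone, it remains open whether the methoxy group of compound 3 matters, which a plain pyridin-3-yl on the carbonyl carbon would test. Going by these compounds, it also remains open whether the same order of these groups would hold with phenyl in place of cyclohexyl on the shared core.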